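Working notes: from 3-fluorophenyl to 2-chlorophenyl in compound 1

The source may report more compounds than this note shows. Statements on the series, on what has been measured and on what is new or still open speak of the compounds shown alone.

Measured so far in a physicochemical assay for solubility, measured as kinetic solubility; on this read-out lower numbers stand for lower solubility and higher numbers for higher solubility:
- compound 1 `CNC(=O)c1cc(C(=O)N[C@H]2CC[C@H](O)CC2)c([C@@H](C)c2cccc(F)c2)o1`: >= 63 ug/mL
- compound 2 `CNC(=O)c1cc(C(=O)NC2CC2)n(Cc2ccccc2)n1`: >= 155 ug/mL

Neither entry is a number. As far as these compounds go, compound 1 stands at a limit of the assay, >= 63 ug/mL, so its true position on the scale remains open. Compound 2 also stands at a limit, >= 155 ug/mL. For the measured compounds named here, the two compounds do not differ in one place, and no measured step in this assay is available as a guide.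

The next compound is compound 3 `CNC(=O)c1cc(C(=O)N[C@H]2CC[C@H](O)CC2)c([C@@H](C)c2ccccc2Cl)o1`, which keeps the core of compound 1. It carries 2-chlorophenyl in place of 3-fluorophenyl on a saturated chain carbon bound to an aromatic carbon and a saturated chain carbon.

Going by the values given here, with no measured step to draw on, the expectation is anchored only on the limit of compound 1, >= 63 ug/mL. The expected step of an at least 1.1-fold lower number from compound 1 to compound 3 (0.05 log units; that floor lies within the scatter) is small, with a slight lean to lower numbers and no size beyond the scatter. For compound 3 the estimated value is 55 ug/mL. The expected range for compound 3 runs from 20 ug/mL to 120 ug/mL. A report as a limit would not be surprising.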

Compound 3, solubility: >= 242 ug/mL
Compound 3 ended at the assay's limit (the forecaster's own chance of this, stated with the estimate: 45%); at least 4.4-fold (0.64 log units) between middle value and limit.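

No step can be read from compound 1 to compound 3 in this assay, since both entries are limits of the assay and not numbers. Compound 3 stands at the limit of >= 242 ug/mL. The compounds shown leave open where compound 1 and compound 3 truly lie on the scale, and whether 2-chlorophenyl in place of 3-fluorophenyl shifts the read-out at all.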